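The compounds below may be only part of what the source reports. "The series", "measured", "known", "first", "only" and "open" are said of these compounds alone.

Working notes on the series. Compound 1 `CCOC(=O)c1cnc(NC2CCCC2)n2nc(-c3ccco3)nc12` gives 35 nM in an assay on CHO cells for displacement of a labelled ligand from adenosine receptor A3 (Homo sapiens); a higher number here means a weaker inhibitor, a lower number a stronger inhibitor. For the measured compounds named here, compound 2 `CCOC(=O)c1cnc(NCCOC)n2nc(-c3ccco3)nc12` gives 105 nM in this assay, the highest of the two numbers so far; its only neighbour is compound 1, and the measured step of a 3.0-fold higher number from compound 1 to compound 2 (0.48 log units; beyond the scatter) is the one reference point. Compound 3 `CCOC(=O)c1cnc(NC2CCCCC2)n2nc(-c3ccco3)nc12` is not yet measured in this assay. The change from compound 2 to compound 3 is cyclohexyl in place of 2-methoxyethyl on a nitrogen on an aromatic ring. This is, in effect, a partial return toward compound 1: a carbocycle again replaces the 2-methoxyethyl chain, one ring size larger than the cyclopentyl of compound 1. Going by the values given here, the single bearing step, from compound 1 to compound 2, ran in the opposite sense and was modest, so a step of about the same size downward is expected, though the larger ring adds some uncertainty. The step expected here is a 2.6-fold lower number from compound 2 to compound 3 (0.42 log units; beyond the scatter). For compound 3 the expected value in this assay is 40 nM, with a range from 15 nM to 110 nM.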

Compound 3, inhibition constant: 131 nM
Compound 3: the middle estimate sits 3.3-fold (0.52 log units) below what was measured; measured number outside the range, above it.
By their numbers in this assay, from the lowest: compound 1; then compounds 2 and 3 (each within the scatter of the next).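

In this assay a carbocycle on this nitrogen does not by itself bring back the number of compound 1: a 1.2-fold higher number from compound 2 to compound 3 (0.10 log units; within the scatter) leaves cyclohexyl and 2-methoxyethyl indistinguishable. Ring size matters within this small set, as a 3.7-fold higher number from compound 1 to compound 3 (0.57 log units; beyond the scatter) shows that cyclohexyl and cyclopentyl are not interchangeable here, and compound 1 alone stands apart from the other two, with both of its steps beyond the scatter. No supporting evidence is available to explain this.

As far as these compounds go, whether the lower number is particular to cyclopentyl or extends to other small rings remains open, and cyclobutyl on the same nitrogen would bear on that. From the compounds shown here alone, whether a ring is needed at all also remains open, and an open-chain pentyl group would help separate the presence of a ring from the carbon count.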